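Sulfonyl side-chain variation at the anilino nitrogen of the shared core

This account rests on a few compounds, and the source may have more. Where it says the series, first, only, none or still open, it means among the compounds named here.

Compound 1 `N=S1(=O)CC(Nc2nonc2/C(=N/O)Nc2ccc(F)c(Br)c2)C1`: 53 nM
Compound 2 `CN(C)S(=O)(=O)CCNc1nonc1/C(=N/O)Nc1ccc(F)c(Br)c1`: 17 nM
Compound 3 `C#CCNS(=O)(=O)CCNc1nonc1/C(=N/O)Nc1ccc(F)c(Br)c1`: 33 nM

All three were measured in an assay on HeLa cells for inhibition of Indoleamine 2,3-dioxygenase 1 (Homo sapiens), read by spectrophotometry, with a stated time of 24 h; a lower number here means that less compound is needed, a higher number that more compound is needed for the effect. Compound 3 stands second highest of the three numbers, within the scatter of both neighbours: the step of a 1.6-fold lower number from compound 1 to compound 3 (0.21 log units; within the scatter) and the step of a 1.9-fold higher number from compound 2 to compound 3 (0.29 log units; within the scatter) both stay within the scatter, while only a 3.1-fold lower number from compound 1 to compound 2 (0.49 log units; beyond the scatter) goes beyond it. Compound 4 `NS(=O)(=O)CCCNc1nonc1/C(=N/O)Nc1ccc(F)c(Br)c1` is not yet measured. Its change from compound 3 is sulfamoylmethyl in place of propargylsulfamoyl on a saturated chain carbon, two bonds along the chain from a nitrogen on an aromatic ring. Going by the values given here, the steps that bear on it, from compound 1 to compound 3 and from compound 2 to compound 3, are small, so no step beyond the scatter is expected for compound 4, in either direction. The estimate for compound 4 in this assay is therefore 32 nM, ranging from 12 nM to 85 nM, corresponding to an expected step of a 1.0-fold lower number from compound 3 to compound 4 (0.01 log units; within the scatter).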

Compound 4, half-maximal effective concentration: 15 nM
Estimate against measurement, compound 4: 2.1-fold (0.33 log units) above; the measured number falls inside the stated range.
By their numbers in this assay, from the lowest: compounds 4, 2, 3 and 1 (each within the scatter of the next, the first and the last beyond it).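

In this assay, going by these compounds alone, the step to 3-sulfamoylpropyl, a 2.2-fold lower number from compound 3 to compound 4 (0.34 log units; beyond the scatter), is the first beyond the scatter among the open-chain sulfonyl compounds. Set against the dimethylsulfamoyl chain, the same kind of change gives a 1.1-fold lower number from compound 2 to compound 4 (0.05 log units; within the scatter), so the two stay level, while a 3.5-fold lower number from compound 1 to compound 4 (0.55 log units; beyond the scatter) shows a gap to the four-membered ring of compound 1 that is also beyond the scatter. Nothing available here accounts for these differences.

The step joins two changes, loss of the propargyl group and growth of the chain from 2-substituted ethyl to 3-sulfamoylpropyl, and the compounds shown do not separate them. Also open, from the compounds shown here alone, is how a carboxylic acid or an amine at the end of the same chain would read.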